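The compounds below may be only part of what the source reports. "The series", "measured", "known", "first", "only" and "open" are said of these compounds alone.

In a functional assay on DU-145 cells (Homo sapiens) for antiproliferative activity, read by sulforhodamine B assay, with a stated time of 3 days (a higher number here means a weaker inhibitor of growth, a lower number a stronger inhibitor of growth), three compounds have numbers: compound 1 `O=C(Nc1cccc(Nc2ncc(F)c(Nc3ccc(F)cc3)n2)c1)c1cnccn1` gives 26400 nM and compound 2 `O=C(c1cccc(Nc2ncc(F)c(Nc3ccc(F)cc3)n2)c1)N1CCCCC1` gives 13000 nM while compound 3 `O=C(Nc1cccc(Nc2ncc(F)c(Nc3ccc(F)cc3)n2)c1)c1ccncc1` gives 4330 nM as the lowest of the three, the strongest inhibitor of growth so far. Compound 4 `CN(C)CC(=O)Nc1cccc(Nc2ncc(F)c(Nc3ccc(F)cc3)n2)c1` is not yet measured. It differs from compound 3 on a carbonyl carbon, where (dimethylamino)methyl stands in place of pyridin-4-yl ((dimethylamino)methyl in place of pyridin-4-yl on a carbonyl carbon). Among the compounds with values here, the closest measured change, on that same carbonyl carbon, is a 6.1-fold lower number from compound 1 to compound 3 (0.79 log units; beyond the scatter) and the broader one is a 3.0-fold lower number from compound 2 to compound 3 (0.48 log units; beyond the scatter) so, with both ending at compound 3 and no measured compound having a ringless group there, a modest rise is expected. The expected change is a 2.1-fold higher number from compound 3 to compound 4 (0.32 log units; beyond the scatter) as an estimate. Compound 4 is estimated at 9000 nM within an expected range from 2500 nM to 30000 nM in this assay's units.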

Compound 4, concentration for 50% growth inhibition: 1210 nM
Compound 4: the middle estimate sits 7.4-fold (0.87 log units) above what was measured, and the stated range ends above it.
By their numbers in this assay, from the lowest: compound 4; then compound 3; then compound 2; then compound 1.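

In this assay, a ring is not needed on this carbonyl carbon: (dimethylamino)methyl in place of pyridin-4-yl gives a 3.6-fold lower number from compound 3 to compound 4 (0.55 log units; beyond the scatter) and in place of pyrazin-2-yl gives a 22-fold lower number from compound 1 to compound 4 (1.34 log units; beyond the scatter) as the largest step here. The amide-linked chain also outdoes the (piperidin-1-yl)carbonyl group, with an 11-fold lower number from compound 2 to compound 4 (1.03 log units; beyond the scatter) among the four compounds shown. No evidence here explains why the ringless group gives the lowest number.
Going by these compounds, how a plain methyl group, a morpholin-4-ylmethyl group or a longer chain ending in the same dimethylamino group would compare on this carbonyl carbon remains open.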